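The source may report more compounds than this note shows. Statements on the series, on what has been measured and on what is new or still open speak of the compounds shown alone.

Values measured in an ADME assay on microsomes from liver (Mus musculus) for metabolic stability, read by LC-MS, using NADPH, with a stated time of 60 min; a lower number here means slower removal, a higher number faster removal of the compound:

Compound 1 `Fc1ccc2[nH]c(Cc3c[nH]c4c(F)cccc34)cc2c1`: 83.9 mL.min-1.g-1
Compound 2 `O=C(c1nc2ccc(F)cc2[nH]1)c1c[nH]c2c(F)cccc12`: 46.5 mL.min-1.g-1
Compound 3 `O=C(c1cc2cc(F)ccc2[nH]1)c1c[nH]c2c(F)cccc12`: 34.6 mL.min-1.g-1

The account follows compound 2, which gives 46.5 mL.min-1.g-1 in this assay. That number lies within the usual scatter of both neighbouring results, that of compound 3 and that of compound 1, so the three-compound set gives it no clear rank against either one.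

The next compound is compound 4 `Cn1c(C(=O)c2c[nH]c3c(F)cccc23)nc2ccc(F)cc21`, not yet measured. It differs from compound 2 in one place, with methyl in place of hydrogen on an aromatic nitrogen. Within the data shown here, no measured pair in this small set shows this change, so the data offer no direct guide to its size. No step beyond the scatter is expected in this assay, with only a slight lean towards faster removal. The expected step is a 1.2-fold higher number from compound 2 to compound 4 (0.07 log units; within the scatter). For compound 4 the estimated value is 55 mL.min-1.g-1, with an expected range from 28 mL.min-1.g-1 to 105 mL.min-1.g-1.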

Compound 4, intrinsic clearance in microsomes: 41.7 mL.min-1.g-1
The estimate for compound 4 lay 1.3-fold (0.12 log units) above the measured number, and the stated range covers the measured number.
By their numbers in this assay, from the lowest: compounds 3, 4, 2 and 1 (each within the scatter of the next, the first and the last beyond it).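

In this assay, methyl in place of hydrogen on an aromatic nitrogen gives a 1.1-fold lower number from compound 2 to compound 4 (0.05 log units; within the scatter), so this nitrogen of the five-membered aromatic ring with 2 nitrogen carries the methyl with no step beyond the scatter. Among these compounds, this is the only pair in the set that differs in one place, and it shows that removing the hydrogen from this nitrogen leaves the read-out indistinguishable from that of the parent. Nothing measured here speaks to the reason for this result.

The compounds shown leave open whether a longer chain on this nitrogen, such as ethyl or a propyl chain ending in an amine, would also stay within the scatter. They also leave open what methyl would do on the other aromatic nitrogen that bears a hydrogen in compound 2.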